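The compounds below may be only part of what the source reports. "The series", "measured", "known", "first", "only" and "open" are said of these compounds alone.

Working notes on the series. Three members of the series have been measured: compound 1 `COc1cc(-c2cc(SC)nc(Nc3nc(N4CCCCC4)nc(N4CCCCC4)n3)n2)cc(OC)c1OC`, compound 2 `COc1cc(-c2cc(SC)nc(Nc3nc(N4CCN(C)CC4)nc(N4CCN(C)CC4)n3)n2)cc(OC)c1OC` and compound 3 `COc1cc(-c2cc(SC)nc(Nc3nc(NC(C)C)nc(NC(C)C)n3)n2)cc(OC)c1OC`. In an ADME assay on J774.A1 cells (Mus musculus) for cytotoxicity, read by MTT assay, with a stated time of 72 h (a higher number here means that more compound is tolerated, a lower number that less compound is tolerated), compound 1 gives 51.7 ug/mL, compound 2 gives 16.5 ug/mL and compound 3 gives 1.9 ug/mL. Compound 2 therefore stands second highest of the three numbers; compound 1 lies above it by a margin beyond the usual scatter, and compound 3 lies below it by a wider margin, also beyond the scatter. Within the data shown here, the three differ from one another only in the groups on the shared core, not on the six-membered aromatic ring of carbon only, so no measured step in this assay speaks to a change on that ring.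

Compound 4 `COc1ccc(-c2cc(SC)nc(Nc3nc(N4CCN(C)CC4)nc(N4CCN(C)CC4)n3)n2)cc1OC` differs from compound 2 in one place: hydrogen in place of methoxy on an aromatic carbon. With no measured step of this kind in the series, the step from compound 2 to compound 4 in this assay is expected to be small, either way, and most likely not beyond the scatter. The estimate for compound 4 in this assay is 14 ug/mL, with a range from 6 ug/mL to 40 ug/mL. The corresponding expected step is a 1.2-fold lower number from compound 2 to compound 4 (0.07 log units; within the scatter).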

Compound 4, half-maximal cytotoxic concentration: 36.2 ug/mL
For compound 4 the middle estimate is 2.6-fold (0.41 log units) below the measured one; the measured number falls inside the stated range.
By their numbers in this assay, from the lowest: compound 3; then compound 2; then compounds 4 and 1 (each within the scatter of the next).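

Among these compounds, the step from 3,4,5-trimethoxyphenyl to 3,4-dimethoxyphenyl is the only measured step on the six-membered aromatic ring of carbon only, and in this assay it reads as a 2.2-fold higher number from compound 2 to compound 4 (0.34 log units; beyond the scatter). The earlier compounds shown here differ only in the groups on the shared core, whereas this result shows that the number also responds to hydrogen in place of methoxy on this ring, modestly but beyond the scatter. No measurement available here bears on why the number moves with this change.

The compounds shown leave open whether the step carries over to the piperidine groups of compound 1 or the isopropylamino groups of compound 3, since it rests on a single pair that keeps the methylpiperazine groups of compound 2. Also open, as far as these compounds go, is how this position behaves with anything other than methoxy or hydrogen, such as a hydroxyl, an amine, a carboxylic acid or a longer chain like ethoxy, and what happens to the number when the remaining methoxy groups on the ring are changed.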